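This account rests on a few compounds, and the source may have more. Where it says the series, first, only, none or still open, it means among the compounds named here.

Of the compounds shown here, two sharing one core have so far been measured in a functional assay on PC-3 cells (Homo sapiens) for cytotoxicity, read by MTT assay, with a stated time of 48 h; a lower number here means a stronger inhibitor, a higher number a weaker inhibitor. Compound 1 `CC1=NN(C(=O)/C=C/c2ccccc2)C(c2ccccc2O)C1` gives 42000 nM in this assay. Among the measured compounds shown here, compound 2 `CC1=NN(C(=O)CCl)C(c2cc(Br)ccc2O)C1` gives 8890 nM in this assay, the lowest of the two numbers; its only neighbour is compound 1, whose number is higher by a gap beyond the usual scatter. Compound 3 `CC1=NN(C(=O)c2ccc(C)cc2)C(c2cc(Br)ccc2O)C1` has not yet been measured. It differs from compound 2 in one place: 4-methylphenyl in place of chloromethyl on a carbonyl carbon. For the measured compounds named here, no step between two measured compounds corresponds to this change, so the expectation rests on the two numbers alone. Compound 3 is expected to give the higher number, the step of a 2.5-fold higher number from compound 2 to compound 3 (0.39 log units; beyond the scatter) being estimated to reach beyond the scatter, though not back to where compound 1 stands. For compound 3 the estimate is 22000 nM, with a range from 7000 nM to 70000 nM.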

Compound 3, half-maximal inhibitory concentration: 41200 nM
For compound 3 the middle estimate is 1.9-fold (0.27 log units) below the measured one; the measured number falls inside the stated range.
By their numbers in this assay, from the lowest: compound 2; then compounds 3 and 1 (each within the scatter of the next).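

Among the compounds shown here, a first step at this position comes from the carbonyl carbon bound to the amide-type nitrogen in a ring: in this assay, 4-methylphenyl in place of chloromethyl brings a 4.6-fold higher number from compound 2 to compound 3 (0.67 log units; beyond the scatter) and so a weaker inhibitor. The position therefore responds to what it carries, and with the rest of the structure unchanged, the group with one six-membered aromatic ring gives the higher number, while the ringless group bearing chlorine gives the lower. Nothing measured here on these compounds bears on why the number moves.

The compounds shown leave open whether the change follows the loss of chlorine, the aromatic ring itself or the methyl on it. They also leave open how an unsubstituted phenyl, a plain methyl, an aminomethyl group or a longer chain would compare on this carbonyl carbon.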